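Aryl Variation on the Shared Core: Methoxy for Chloro

The source may hold more compounds than are shown below. What is called first, only, known or untested is meant among the compounds shown, and "the series" means these compounds.

Compound 1 `c1ccc(-c2cn3ccnc3c(-c3ccc4ncn(C5CCCCC5)c4c3)n2)cc1` carries an unsubstituted phenyl on the shared core; in a functional assay on Hs-578T cells (Homo sapiens) for inhibition, read by sulforhodamine B assay, with a stated time of 48 h, tested at 10 uM (a lower number here means less inhibition, a higher number more inhibition at the concentration tested (going by the name of the read-out)), compound 1 gives 23.8%. Compound 2 `Clc1ccc(-c2cn3ccnc3c(-c3ccc4ncn(C5CCCCC5)c4c3)n2)cc1` differs only by chloro in place of hydrogen on an aromatic carbon, and in this assay compound 2 gives 6.35%. Among the compounds with values here, the one measured step is a number 17.5 percentage points lower from compound 1 to compound 2 (beyond the scatter). Within the data shown here, on the numbers so far compound 2 stands lowest of the two, its only neighbour being compound 1, higher by a margin beyond the scatter.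

Compound 3 `COc1ccccc1-c1cn2ccnc2c(-c2ccc3ncn(C4CCCCC4)c3c2)n1` is not yet measured. Its change from compound 2 is 2-methoxyphenyl in place of 4-chlorophenyl on an aromatic carbon. Among the measured compounds shown here, the only step that bears on it is the hydrogen-to-chloro exchange, of modest size, which covers the loss of the chlorine but says nothing about the incoming methoxy group on its own aromatic carbon. Removal of the chloro alone would point back toward the number of compound 1, and the methoxy is an unknown.

Compound 3 is therefore expected to give about 18%, within 0% to 40%. The estimated step is a number 11.7 percentage points higher from compound 2 to compound 3 (beyond the scatter), upward but uncertain.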

Compound 3, a percentage reported as inhibition, at one concentration (the size of the read-out at that concentration, not a potency): 15.8%
Estimate against measurement, compound 3: 2.2 percentage points above; the range from low to high includes it.
By their numbers in this assay, from the lowest: compounds 2, 3 and 1 (each within the scatter of the next, the first and the last beyond it).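

Notes on the aryl position: in this assay the exchange of 4-chlorophenyl for 2-methoxyphenyl gives a number 9.5 percentage points higher from compound 2 to compound 3 (within the scatter) and methoxy in place of hydrogen gives a number 8 percentage points lower from compound 1 to compound 3 (within the scatter), so compound 3 cannot be told apart from either neighbour, even though those two neighbours are separated by a number 17.5 percentage points lower from compound 1 to compound 2 (beyond the scatter). This aromatic carbon of the shared core therefore accepts 2-methoxyphenyl with no step beyond the scatter from either the unsubstituted phenyl or 4-chlorophenyl, and the chloro exchange remains the only step among these three compounds that lies beyond it. Nothing at hand gives a reason for any of these readings.

The 4-chlorophenyl and 2-methoxyphenyl groups differ both in the substituent and in its place on the phenyl ring, so the compounds shown cannot separate the effect of the group from the effect of where it sits. Also open, on these data alone, is how the series would read with an amine or a carboxylic acid on that phenyl ring, and whether a longer chain in place of the methoxy would stay within the scatter of compound 3.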